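From methyl to propyl on compound 1

This account rests on a few compounds, and the source may have more. Where it says the series, first, only, none or still open, it means among the compounds named here.

- compound 1 `CN1CCN(c2ccc(S(=O)(=O)Oc3cc(Cl)c(Cl)cc3Cl)cc2)C1=O` gives 420 nM
- compound 2 `CN1CCN(c2ccc(S(=O)(=O)Oc3ccc(F)cc3)cc2)C1=O` gives > 100000 nM, a limit of the assay

Both compounds were tested in a functional assay on M21 cells (Homo sapiens) for antiproliferative activity, read by sulforhodamine B assay, with a stated time of 48 h; on this read-out lower numbers stand for stronger inhibition and higher numbers for weaker inhibition. Going by the values given here, compound 1 holds the only true number here, 420 nM, so it serves as the single reference point. Compound 2 reached only a limit, > 100000 nM, and this is not a number.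

Compound 3 `CCCN1CCN(c2ccc(S(=O)(=O)Oc3cc(Cl)c(Cl)cc3Cl)cc2)C1=O` has not yet been measured. It keeps the core of compound 1 and changes one group, methyl to propyl: ethyl in place of hydrogen on a saturated chain carbon bound to an amide-type nitrogen in a ring. Among the compounds with values here, no measured pair shows what this change does, so the expectation rests on compound 1 alone, at 420 nM. The expected step of a 1.4-fold higher number from compound 1 to compound 3 (0.15 log units; within the scatter) is small, within the usual scatter, with a slight lean towards weaker inhibition. For compound 3 the estimated value is 600 nM, with an expected range from 150 nM to 2500 nM.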

Compound 3, half-maximal inhibitory concentration: 15000 nM
Beside the measured number, compound 3's estimate is 25-fold (1.40 log units) below it, outside the stated range (above it).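

Extending methyl to propyl, on a saturated chain carbon bound to an amide-type nitrogen in a ring, brings a 36-fold higher number from compound 1 to compound 3 (1.55 log units; beyond the scatter) in this assay. Going by these compounds alone, this is the first measured sign that this position is sensitive: an added ethyl of only 2 heavy atoms weakens inhibition well beyond the usual scatter, although compound 3 still gives a true number, 15000 nM, and not a limit. Nothing measured here accounts for the size of this step.

As far as these compounds go, the effect of an ethyl, of a longer chain such as butyl, or of a chain ending in an amine or a hydroxyl group at this position remains open. From the compounds shown here alone, it is also open whether the loss grows steadily with chain length or appears suddenly at propyl.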